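The source may report more compounds than this note shows. Statements on the series, on what has been measured and on what is new or still open speak of the compounds shown alone.

Compound 1, `CCCC[C@H](C)C[C@H](O)/C=C/[C@H]1CCC(=O)N1CCSc1nc(C(=O)O)cs1`: 310 nM
Compound 2, `O=C(O)c1csc(SCCN2C(=O)OC[C@@H]2/C=C/[C@@H](O)C2(CCc3ccccc3)CCC2)n1`: 27 nM

Both were tested in an assay on isolated protein for agonist activity at prostaglandin E2 receptor EP3 subtype (Homo sapiens); on this read-out higher numbers stand for an effect only at larger amounts of compound and lower numbers for an effect already at smaller amounts. Of the two numbers, compound 2 gives the lower one, and compound 1 lies beyond the usual scatter above it. Compound 3, `CCCCC1([C@H](O)/C=C/[C@H]2COC(=O)N2CCSc2nc(C(=O)O)cs2)CCC1`, has not yet been measured. It differs from compound 2 in one place: ethyl in place of phenyl on a saturated chain carbon, two bonds along the chain from a saturated ring carbon. Going by the values given here, no measured pair of compounds shows this change by itself, so the direction rests on the two numbers alone. A modest rise in the number, toward weaker activity, is expected, a 3.0-fold higher number from compound 2 to compound 3 (0.47 log units; beyond the scatter). Compound 3 is estimated at 80 nM, within a range from 25 nM to 250 nM.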

Compound 3, half-maximal effective concentration: 3.9 nM
Beside the measured number, compound 3's estimate is 21-fold (1.31 log units) above it; measured number outside the range, below it.
By their numbers in this assay, from the lowest: compound 3; then compound 2; then compound 1.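

Replacing phenyl with ethyl at this saturated chain carbon, two bonds along the chain from a saturated ring carbon, gives a 6.9-fold lower number from compound 2 to compound 3 (0.84 log units; beyond the scatter) in this assay and shows that the phenyl ring is not needed for activity here. Read one bond further out, butyl serves better than phenethyl, though only this single pair shows it. No measurement shown explains this gain.

On these data alone, whether a shorter methyl or a longer hexyl chain would lower the number further remains open. So does whether a cyclohexyl ring would keep this activity.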